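A few compounds are considered here, and "the series" means these few. Any claim that something is new, unique, unknown or untested is made for them only; others in the source may bear on it.

This piece follows a single change made to compound 2 `COc1cc(-c2nn(-c3cccc(NC(=O)c4cccc(C(F)(F)F)c4)c3)cc2-c2ccncc2)ccc1Cl`, read in a functional assay on Malme-3M cells (Homo sapiens) for inhibition, read by sulforhodamine B assay, with a stated time of 48 h; a higher number here means that more compound is tolerated, a lower number that less compound is tolerated. Compound 2 gives only a limit in this assay, > 50000 nM, so its standing can be described only as a limit, not as a number. The related compound 1 `O=C(Nc1cccc(-n2cc(-c3ccncc3)c(-c3ccc(Cl)c(O)c3)n2)c1)Nc1cccc(C(F)(F)F)c1` likewise gives only a limit in this assay, > 32500 nM. Both compounds therefore sit at limits, the limit of > 32500 nM in this assay, at which 1 of the 2 values shown sits, and (the limit of > 50000 nM in this assay, at which 1 of the 2 values shown sits), and no ordering between the two can be read from these numbers.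

The change leading to compound 3 `COc1cc(-c2nn(-c3cccc(NC(=O)Nc4ccc(Cl)c(Cl)c4)c3)cc2-c2ccncc2)ccc1Cl` is (3,4-dichlorophenyl)amino in place of 3-(trifluoromethyl)phenyl on a carbonyl carbon; in plain words, the amide of compound 2 becomes a urea that carries a 3,4-dichlorophenyl ring. Within the data shown here, no measured pair shows a change of this kind, so the size of such a step is not known from the data. Compound 2 itself sits at a limit, > 50000 nM. On that basis the step from compound 2 to compound 3 is expected to be a number no higher from compound 2 to compound 3 (the limit leaves the size open), most likely none beyond the scatter. Compound 3 is thus expected to give 50000 nM in this assay, with a range from 15000 nM to 150000 nM, and quite probably again only a limit.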

Compound 3, concentration lethal to 50% of the cells: > 50000 nM
Compound 3: only a limit was reported; the forecaster's own chance of this, stated with the estimate: 75%; the middle value sits exactly at the limit.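

In this assay compound 3 gives > 50000 nM as a limit only. Compound 2 also gives only a limit, so no step can be read between compound 2 and compound 3. The compounds shown leave open whether any of them has a measurable lethal concentration in this assay and what the change from amide to urea does to it.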